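This account rests on a few compounds, and the source may have more. Where it says the series, first, only, none or still open, it means among the compounds named here.

Within the data shown here, in a functional assay on MCF7 cells (Homo sapiens) for antiproliferative activity, read by MTT assay, with a stated time of 48 h (a lower number here means a stronger inhibitor, a higher number a weaker inhibitor), compound 1 `N=C(N)N/N=C(/C=C/c1ccc(F)cc1)c1ccccc1` gives 2500 nM and compound 2 `N=C(N)N/N=C(/C=C/c1ccc(-c2ccccc2)cc1)c1ccccc1` gives 800 nM as the lower of the two numbers so far. Among the measured compounds shown here, the one measured step is a 3.1-fold lower number from compound 1 to compound 2 (0.49 log units; beyond the scatter) for phenyl in place of fluoro on an aromatic carbon, which is modest yet beyond the usual scatter. Compound 3 `Cc1ccc(/C=C/C(=N/NC(=N)N)c2ccccc2)cc1` is still unmeasured and differs from compound 2 by methyl in place of phenyl on an aromatic carbon, para to a large group (methyl in place of phenyl on an aromatic carbon). For the measured compounds named here, no measured compound carries methyl, so the only guide is the reverse of that single step, with phenyl leaving. A modest move to a higher number is therefore expected, back toward compound 1 at 2500 nM in this assay. The expected size is a 2.8-fold higher number from compound 2 to compound 3 (0.44 log units; beyond the scatter) as an estimate only. Compound 3 is estimated at 2200 nM as the expected value (range 1000 nM to 5000 nM).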

Compound 3, half-maximal inhibitory concentration: 16000 nM
Estimate against measurement, compound 3: 7.3-fold (0.86 log units) below; the whole stated range lies below it.
By their numbers in this assay, from the lowest: compound 2; then compound 1; then compound 3.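

In this assay, the change at this position costs far more than the earlier step suggested, with a 20-fold higher number from compound 2 to compound 3 (1.30 log units; beyond the scatter). Phenyl's departure therefore does not simply undo the gain seen with fluoro, since methyl also falls short of fluoro, with a 6.4-fold higher number from compound 1 to compound 3 (0.81 log units; beyond the scatter); the two groups without a ring are not interchangeable here, and this place responds to the identity of the group, not only to whether a phenyl ring is present. Nothing shown gives a measured reason for this order of phenyl, fluoro and methyl.

Three groups on one aromatic carbon give only a narrow view of this position. As far as these compounds go, whether a methoxy group, an amine or a longer chain would sit nearer phenyl or nearer methyl remains open, as does whether a ring other than phenyl would match compound 2.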